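The source may report more compounds than this note shows. Statements on the series, on what has been measured and on what is new or still open speak of the compounds shown alone.

In a functional assay on SK-BR-3 cells (Homo sapiens) for antiproliferative activity (on this read-out higher numbers stand for weaker inhibition and lower numbers for stronger inhibition), compound 1 (`CC(C)=CCc1cc(C(=O)Nc2cc3ccc(OCCC4CCCCN4)c(C)c3oc2=O)ccc1O`) gives 640 nM, compound 2 (`CCCNCCCOc1ccc2cc(NC(=O)c3ccc(O)c(CC=C(C)C)c3)c(=O)oc2c1C`) gives 990 nM and compound 3 (`CC(C)=CCc1cc(C(=O)Nc2cc3ccc(OCCCNC(C)C)c(C)c3oc2=O)ccc1O`) gives 750 nM, which puts compound 3 within the scatter of both others. Compound 4 (`COC(=O)CNCCCOc1ccc2cc(NC(=O)c3ccc(O)c(CC=C(C)C)c3)c(=O)oc2c1C`) differs from compound 3 as follows: (methoxycarbonyl)methyl in place of isopropyl on an amine nitrogen. This places (methoxycarbonyl)methyl in place of isopropyl on an amine nitrogen. The closest measured change, a 1.3-fold lower number from compound 2 to compound 3 (0.12 log units; within the scatter), concerns the same nitrogen and stays within the scatter, as do a 1.5-fold higher number from compound 1 to compound 2 (0.19 log units; within the scatter) and a 1.2-fold higher number from compound 1 to compound 3 (0.07 log units; within the scatter). Among the measured compounds shown here, no measured step brings in a (methoxycarbonyl)methyl group, so the range stays wide, and only a modest move towards a higher number in this assay is expected. The expected change is a 1.3-fold higher number from compound 3 to compound 4 (0.12 log units; within the scatter). Compound 4 is estimated at 1000 nM, with an expected range of 400 nM to 2500 nM.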

Compound 4, half-maximal inhibitory concentration: 1060 nM
Compound 4: the middle estimate sits 1.1-fold (0.03 log units) below what was measured; the measured number falls inside the stated range.
By their numbers in this assay, from the lowest: compounds 1, 3, 2 and 4 (each within the scatter of the next).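

On the amine nitrogen of the shared core, a (methoxycarbonyl)methyl group, the only substituent here carrying oxygen, fits the flat picture in this assay: a 1.4-fold higher number from compound 3 to compound 4 (0.15 log units; within the scatter), a 1.1-fold higher number from compound 2 to compound 4 (0.03 log units; within the scatter) and a 1.7-fold higher number from compound 1 to compound 4 (0.22 log units; within the scatter). Swapping simple alkyl for this ester-bearing group therefore leaves the read-out within the scatter of all three earlier compounds. Nothing available explains this result.

As far as these compounds go, whether a carboxylic acid or a longer chain on this nitrogen would move the number beyond the scatter remains open. With all four compounds within the scatter, the substituents on this nitrogen cannot be ranked.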